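Chloro to methyl on the anilino ring of compound 2

This account rests on a few compounds, and the source may have more. Where it says the series, first, only, none or still open, it means among the compounds named here.

Compound 2 `COc1cc(/C=C/C(=O)c2sc(Nc3cccc(Cl)c3)nc2C)cc(OC)c1OC` gives 11600 nM in a functional assay on BGC-823 cells (Homo sapiens) for cytotoxicity, read by MTT assay (a lower number here means a stronger inhibitor, a higher number a weaker inhibitor), the lowest of the two numbers in hand. Compound 1 `COc1cccc(/C=C/C(=O)c2sc(Nc3ccccc3)nc2C)c1` gives 14300 nM in this assay, and the gap between compound 1 and compound 2 lies within the scatter, so the two read as equal. Compound 3 `Cc1cccc(Nc2nc(C)c(C(=O)/C=C/c3ccc(Cl)cc3)s2)c1` reaches only the limit of this assay, > 25000 nM; the limit of > 25000 nM in this assay, at which 1 of the 3 values shown sits, marks that value as a limit and not a number. Among the compounds with values here, compound 3 and compound 2 differ in more than one place, so their two values show no single step.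

Compound 4 `COc1cc(/C=C/C(=O)c2sc(Nc3cccc(C)c3)nc2C)cc(OC)c1OC` differs from compound 2 by methyl in place of chloro on an aromatic carbon, meta to a large group. Within the data shown here, no measured step covers this change. Compound 3 carries the same methyl on that ring and sits at the limit, so a step toward a weaker inhibitor, of modest size, is expected from compound 2 to compound 4, a 1.4-fold higher number from compound 2 to compound 4 (0.14 log units; within the scatter). Compound 4 is estimated at 16000 nM in this assay, within 7000 nM to 40000 nM.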

Compound 4, half-maximal inhibitory concentration: 17200 nM
Compound 4: the middle estimate sits 1.1-fold (0.03 log units) below what was measured; the range from low to high includes it.
By their numbers in this assay, from the lowest: compounds 2, 1 and 4 (each within the scatter of the next). At a limit, above all of these: compound 3.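

Within the data shown here, on an aromatic carbon meta to a large group, methyl in place of chloro gives the first single-place step, and in this assay the two groups read as equal: a 1.5-fold higher number from compound 2 to compound 4 (0.17 log units; within the scatter). With the rest of the structure held fixed, this exchange of one heavy atom for one heavy atom, with no hydrogen-bond donor or acceptor on either side, leaves the number within the scatter. Compound 3 carries the same methyl but differs from compound 4 in more than one place, and its value stays a limit and not a number: the limit of > 25000 nM in this assay, at which 1 of the 4 values shown sits.

From the compounds shown here alone, whether an amine or a carboxylic acid at this place would move the number beyond the scatter stays open. The steps among the other compounds cannot be read, so the contribution of the remaining substitution is also unresolved.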